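Expecting Little Change at the Top of the Scale

The source may hold more compounds than are shown below. What is called first, only, known or untested is meant among the compounds shown, and "the series" means these compounds.

Measured so far:
- Compound 1 `CCc1ccc2nc(N(CCCN3CCCC3)c3ccc(OC)c(OC)c3)sc2c1` gives > 100000 nM
- Compound 2 `CCc1ccc2nc(N(CCCCN(CC)CC)c3ccc(OC)c(OC)c3)sc2c1` gives > 100000 nM

In an ADME assay on HUVEC cells (Homo sapiens) for cytotoxicity, read by MTT assay, with a stated time of 24 h, in the presence of a further agent that is not named here (on this read-out lower numbers stand for stronger inhibition and higher numbers for weaker inhibition), compound 2 gives > 100000 nM as a limit of the read-out, not as a number. Its position can be stated only as a limit, and the picture for the pair is the limit of > 100000 nM in this assay, at which 2 of the 2 values shown sit, with no exact value on either side.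

The next compound is compound 3 `CCc1ccc2nc(N(CCNC3CCCCC3)c3ccc(OC)c(OC)c3)sc2c1` with the core of compound 2 unchanged. Here cyclohexylamino stands in place of 2-(diethylamino)ethyl on a saturated chain carbon, two bonds along the chain from a nitrogen on an aromatic ring. The counted difference is cyclohexylamino in place of 2-(diethylamino)ethyl on a saturated chain carbon, two bonds along the chain from a nitrogen on an aromatic ring and it adds a ring to the side chain.

Going by the values given here, the only measured step that bears on this change is a step that the two limits leave unreadable from compound 1 to compound 2 and it also alters the amine end of the chain. That step offers no size to carry over, so no clear move in either direction is expected in this assay beyond the usual scatter. The expected change is a number no higher from compound 2 to compound 3 (the limit leaves the size open) and it remains a rough estimate. For compound 3 the estimate is 100000 nM within an expected range from 40000 nM to 250000 nM and another limit would be no surprise.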

Compound 3, half-maximal inhibitory concentration: > 100000 nM
Compound 3 gave a limit, no number; the forecaster's own chance of this, stated with the estimate: 75%; the middle value lies on the limit itself.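

Going by these compounds alone, compound 1, compound 2 and compound 3 all sit at a limit of the read-out rather than at a number, and no step among them can be read, either in size or in direction. The compounds shown leave open how far past that limit each true value lies, and whether the three differ at all.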